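A few compounds are considered here, and "the series" means these few. Any claim that something is new, unique, unknown or untested is made for them only; others in the source may bear on it.

In an ADME assay on a cell-free system (plasma, Homo sapiens) (on this read-out lower numbers stand for a smaller free fraction and higher numbers for a larger free fraction), compound 1 (`CCNC(=O)Nc1nc2cc(-c3cncnc3)c(=O)n(C(C)C)c2s1`) gives 0.15 and compound 2 (`CCNC(=O)Nc1nc2cc(-c3cncc(OC)c3)c(=O)n(C(C)C)c2s1`) gives 0.08, so these two values lie within the scatter of each other. Compound 3 (`CCNC(=O)Nc1nc2cc(-c3cncc(C#N)c3)c(=O)n(C(C)C)c2s1`) carries cyano in place of methoxy on an aromatic carbon, two atoms from the ring nitrogen: cyano in place of methoxy on an aromatic carbon. The same difference reads 5-methoxypyridin-3-yl to 5-cyanopyridin-3-yl. For the measured compounds named here, no measured step covers this exact exchange. Going by the values given here, the nearest evidence is the single change of this aromatic group, 5-methoxypyridin-3-yl in place of pyrimidin-5-yl, measured as a 1.9-fold lower number from compound 1 to compound 2 (0.27 log units; within the scatter). On that one step, no shift beyond the scatter is expected in this assay, and any direction is tentative. The estimated change is a 1.4-fold higher number from compound 2 to compound 3 (0.14 log units; within the scatter). For compound 3 the expected value is 0.11, with an estimated range of 0.06 to 0.2.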

Compound 3, unbound fraction: 0.1
For compound 3 the middle estimate is 1.1-fold (0.04 log units) above the measured one; low and high end bracket the measured number.
By their numbers in this assay, from the lowest: compounds 2, 3 and 1 (each within the scatter of the next).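

In this assay, cyano and methoxy on the aromatic carbon two atoms from the ring nitrogen cannot be told apart (a 1.3-fold higher number from compound 2 to compound 3 (0.10 log units; within the scatter)), so this exchange of two groups of equal heavy-atom count leaves the unbound fraction within the scatter. The 5-cyanopyridin-3-yl group also cannot be told apart from pyrimidin-5-yl (a 1.5-fold lower number from compound 1 to compound 3 (0.18 log units; within the scatter)), so all three aromatic groups shown now lie within the scatter of one another, and no step at this place yet separates any pair. No supporting measurement bears on why these compounds read alike.

Still open, from the compounds shown here alone, is whether an amine or a carboxylic acid on this same carbon would move the unbound fraction beyond the scatter. Also open, going by these compounds, is how far changes elsewhere on the shared core would do so.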